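Fluorine pattern change on the phenylcarbonyl: compound 2 to compound 3

The source may hold more compounds than are shown below. What is called first, only, known or untested is meant among the compounds shown, and "the series" means these compounds.

Measured so far:
compound 1 `CN(C(=O)NC(=O)c1cccc(C(F)(F)F)c1)c1nc(C(F)(F)F)c(C(=O)N/N=C/c2ccc(C(F)(F)F)cc2)s1` — 7.71 ug/mL
compound 2 `CN(C(=O)NC(=O)c1ccccc1F)c1nc(C(F)(F)F)c(C(=O)N/N=C/c2cc(C(F)(F)F)cc(C(F)(F)F)c2)s1` — 4.47 ug/mL

In a functional assay on HepG2 cells (Homo sapiens) for inhibition, read by MTT assay, with a stated time of 72 h (on this read-out higher numbers stand for weaker inhibition and lower numbers for stronger inhibition), compound 1 gives 7.71 ug/mL and compound 2 gives 4.47 ug/mL. Compound 2 stands at the smaller of the two numbers, but compound 1 lies within the scatter of it, so the two cannot be told apart on these data. Compound 3 `CN(C(=O)NC(=O)c1ccc(F)c(F)c1)c1nc(C(F)(F)F)c(C(=O)N/N=C/c2cc(C(F)(F)F)cc(C(F)(F)F)c2)s1` is the next member: 3,4-difluorophenyl in place of 2-fluorophenyl on a carbonyl carbon. Going by the values given here, no measured pair shows what this kind of change does here, and the shared core with its trifluoromethyl-bearing hydrazone portion is held constant. With nothing pointing either way, the step of a 1.0-fold higher number from compound 2 to compound 3 (0.00 log units; within the scatter) is expected to stay within the scatter, in no particular direction. Compound 3 is therefore estimated at 4.5 ug/mL, with a range of 2 ug/mL to 10 ug/mL, to be checked when compound 3 is measured in this assay.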

Compound 3, half-maximal inhibitory concentration: 5.47 ug/mL
Compound 3: middle estimate off by 1.2-fold (0.08 log units), on the low side, within the range that was stated.
By their numbers in this assay, from the lowest: compounds 2, 3 and 1 (each within the scatter of the next).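

In this assay, going by these compounds alone, the one pair that differs in a single place gives a 1.2-fold higher number from compound 2 to compound 3 (0.09 log units; within the scatter) for 3,4-difluorophenyl in place of 2-fluorophenyl on a carbonyl carbon, so the two compounds cannot be told apart. With the rest of the structure held constant, this place, on a carbonyl carbon whose other neighbour is an amide-type nitrogen, accepts this change of fluorine pattern and fluorine count without a reading beyond the scatter. Nothing available here bears on the cause of this result.

The compounds shown leave open whether a phenyl group carrying a carboxylic acid or a dimethylamino group at this place would stay within the same scatter. Also open, on these data alone, is whether the same exchange would read alike on a different hydrazone portion.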